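Swapping a hydroxyphenyl for a trimethoxyphenyl on the pyrazoline

This account rests on a few compounds, and the source may have more. Where it says the series, first, only, none or still open, it means among the compounds named here.

Compound 1 `Cc1cc(O)c(C2=NN(c3ccc(S(N)(=O)=O)cc3)C(c3ccccc3O)C2)cc1Cl` is the starting point. In a functional assay on SK-OV-3 cells (Homo sapiens) for antiproliferative activity, with a stated time of 48 h (a higher number here means a weaker inhibitor of growth, a lower number a stronger inhibitor of growth), compound 1 gives 14900 nM. Within the data shown here, the one comparison available comes from compound 2 `Cc1cc(O)c(C2=NN(c3ccc(S(N)(=O)=O)cc3)C(/C=C/c3ccccc3)C2)cc1Cl`, which in this assay gives 17900 nM; the change a 1.2-fold higher number from compound 1 to compound 2 (0.08 log units; within the scatter) keeps both values within the usual scatter of each other, so neither can be set apart from the other. Compound 3 `COc1ccc(C2CC(c3cc(Cl)c(C)cc3O)=NN2c2ccc(S(N)(=O)=O)cc2)c(OC)c1OC` differs from compound 1 by 2,3,4-trimethoxyphenyl in place of 2-hydroxyphenyl on a saturated ring carbon. Among the measured compounds shown here, the step from compound 1 to compound 2 is the only measured change at this same saturated ring carbon, and it produced no movement beyond the scatter, which suggests this position tolerates different groups without a clear change in growth inhibition. The step of a 1.1-fold higher number from compound 1 to compound 3 (0.03 log units; within the scatter) is therefore expected to be small, with no clear direction. Compound 3 is estimated at 16000 nM in this assay, with a likely range of 5000 nM to 50000 nM.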

Compound 3, concentration for total growth inhibition: 11400 nM
The estimate for compound 3 lay 1.4-fold (0.15 log units) above the measured number, within the range that was stated.
By their numbers in this assay, from the lowest: compounds 3, 1 and 2 (each within the scatter of the next).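

In this assay, the step from the smaller group to the larger one stays within the scatter: a 1.3-fold lower number from compound 1 to compound 3 (0.12 log units; within the scatter), and a 1.6-fold lower number from compound 2 to compound 3 (0.20 log units; within the scatter). This saturated ring carbon can therefore carry 2,3,4-trimethoxyphenyl, with 12 heavy atoms and 0 hydrogen-bond donors, in place of 2-hydroxyphenyl, with 7 heavy atoms and 1 hydrogen-bond donor, without a clear change in growth inhibition, so compounds 1, 2 and 3 cannot be told apart here. No measurement is available that explains this lack of response.

On these data alone, all three groups at this carbon carry an aromatic ring of carbon only, so it remains open how an amine, a carboxylic acid or a plain alkyl chain would behave there. As far as these compounds go, the 5-chloro-2-hydroxy-4-methylphenyl and 4-sulfamoylphenyl groups stay the same throughout, so their contribution to growth inhibition also remains open.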